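Working notes: from compound 1 to compound 3

The source may report more compounds than this note shows. Statements on the series, on what has been measured and on what is new or still open speak of the compounds shown alone.

- Compound 1 `Fc1ccc(N2CCN(CCN3CCN(c4ccc(F)cc4)CC3)CC2)cc1` gives 71200 nM
- Compound 2 `O=[N+]([O-])c1cc(C(F)(F)F)ccc1N1CCN(CCCN2CCN(c3ccc(C(F)(F)F)cc3[N+](=O)[O-])CC2)CC1` gives 12200 nM

In a functional assay on LNCaP cells (Homo sapiens) for cytotoxicity, read by MTT assay, with a stated time of 24 h (a lower number here means that less compound is needed, a higher number that more compound is needed for the effect), compound 1 stands highest of the two numbers, and compound 2 lies lower by more than the usual scatter. Compound 3 `COc1ccccc1N1CCN(CCN2CCN(c3ccc(F)cc3)CC2)CC1` has not yet been measured. It carries 2-methoxyphenyl in place of 4-fluorophenyl on an amine nitrogen in a ring. Among the measured compounds shown here, no measured pair isolates this change, and compound 2 differs from compound 1 in more than one place. No shift beyond the scatter is therefore expected in this assay, with a slight lean to a lower number, since compound 1 at 71200 nM holds the higher of the two values. The expected change is a 1.6-fold lower number from compound 1 to compound 3 (0.20 log units; within the scatter) and stays within the scatter. The estimate for compound 3 is 45000 nM (expected range 15000 nM to 130000 nM).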

Compound 3, half-maximal effective concentration: 78700 nM
Estimate against measurement, compound 3: 1.7-fold (0.24 log units) below; low and high end bracket the measured number.
By their numbers in this assay, from the lowest: compound 2; then compounds 1 and 3 (each within the scatter of the next).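

In this assay, among the compounds shown here, 2-methoxyphenyl in place of 4-fluorophenyl on an amine nitrogen in a ring gives a 1.1-fold higher number from compound 1 to compound 3 (0.04 log units; within the scatter), the only step so far that isolates a single place. At this position, then, the exchange of these two groups leaves the read-out within the scatter, which the earlier pair of compounds could not show. For the compounds shown here, the entering group counts one more heavy atom and one hydrogen-bond acceptor where 4-fluorophenyl has none, yet this difference comes with no shift beyond the scatter here, and nothing measured so far explains the result.

The step to compound 2 cannot be read, as that compound differs from compound 1 in more than one place. Open, on these data alone, is whether a carboxylic acid or an amine on the aromatic ring at this position would give a shift beyond the scatter.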